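This account rests on a few compounds, and the source may have more. Where it says the series, first, only, none or still open, it means among the compounds named here.

Two compounds carry numbers in an ADME assay on HepG2 2.2.15 cells (Homo sapiens) for cytotoxicity; on this read-out higher numbers stand for lower toxicity in this test and lower numbers for higher toxicity in this test. Compound 1 `O=c1c(CCO)c(-c2ccccc2Cl)c2cc(Cl)ccc2n1-c1c(F)cccc1F` gives only a limit of the test, > 2300000 nM. For the measured compounds named here, compound 2 `CCOCC(=O)OCCc1c(-c2ccccc2Cl)c2cc(Cl)ccc2[nH]c1=O` gives 130000 nM in this assay, the sole number in the set. The other value, that of compound 1, is a limit (the limit of > 2300000 nM in this assay, at which 1 of the 2 values shown sits). Compound 3 `O=C(OCCc1c(-c2ccccc2Cl)c2cc(Cl)ccc2[nH]c1=O)c1cccs1` differs from compound 2 by thiophen-2-yl in place of ethoxymethyl on a carbonyl carbon. Going by the values given here, no measured step between compounds is available to anchor this change; the expectation is a small shift from compound 2 toward greater toxicity, of about a 1.4-fold lower number from compound 2 to compound 3 (0.16 log units; within the scatter), which may stay within the scatter. Compound 3 is therefore estimated at 90000 nM, in the range 25000 nM to 350000 nM.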

Compound 3, half-maximal cytotoxic concentration: > 1700000 nM
Compound 3 gave a limit, no number; the forecaster's own chance of this, stated with the estimate: 10%; middle value at least 18-fold (1.27 log units) away from the limit.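

On this carbonyl carbon, thiophen-2-yl in place of ethoxymethyl is not a neutral swap in this assay: the change gives an at least 13-fold higher number from compound 2 to compound 3 (1.11 log units; beyond the scatter), toward lower toxicity in this test. Compound 3 reads > 1700000 nM, which is a limit of the test and not a number. The step is therefore only a lower bound on the shift: the limit of > 1700000 nM in this assay, at which 1 of the 3 values shown sits.

On these data alone, whether a phenyl ring, a longer alkyl chain or an amine on the same carbonyl carbon moves the read-out likewise stays open. The compounds shown also do not separate the gain of the thiophene ring from the loss of ethoxymethyl.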